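Aryloxy variation in an acylphenol series: chloro-carboxyphenyl to methoxyphenyl

The source may report more compounds than this note shows. Statements on the series, on what has been measured and on what is new or still open speak of the compounds shown alone.

Of the compounds shown here, three have been measured in an assay for positive allosteric modulation of metabotropic glutamate receptor 3 (Rattus norvegicus); on this read-out lower numbers stand for an effect already at smaller amounts and higher numbers for an effect only at larger amounts of compound. Compound 1 `COc1ccc(C(=O)O)cc1OC[C@@H](C)Oc1ccc(C(=O)CC(C)(C)C)c(O)c1C` gives 806 nM, compound 2 `COc1ccc(C(=O)O)cc1OC[C@H](C)COc1ccc(C(=O)CC(C)(C)C)c(O)c1C` gives 384 nM, and compound 3 `Cc1c(OC[C@@H](C)COc2ccc(Cl)c(C(=O)O)c2)ccc(C(=O)CC(C)(C)C)c1O` gives 2200 nM. Compound 3 therefore stands highest of the three numbers; compound 1 lies nearest to it and compound 2 furthest, both differences reaching beyond the usual scatter. Among the compounds with values here, no two of the measured compounds differ in a single place, so no measured single step is available.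

Compound 4 `COc1cccc(OC[C@H](C)COc2ccc(C(=O)CC(C)(C)C)c(O)c2C)c1` is not yet measured. It differs from compound 3 in one place: 3-methoxyphenyl in place of 3-carboxy-4-chlorophenyl on an oxygen on a saturated carbon. The 3-carboxy-4-chlorophenyl group is present in no other form among the measured compounds, so there is no measured comparator for its removal. A step toward a higher number, beyond the scatter, is expected for a 2.3-fold higher number from compound 3 to compound 4 (0.36 log units; beyond the scatter) in this assay. For compound 4 the estimate in this assay is 5000 nM, with an expected range from 1200 nM to 25000 nM.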

Compound 4, half-maximal effective concentration: "not active" (no number reported)
The entry for compound 4 holds no number, so the estimate cannot be set against anything.
By their numbers in this assay, from the lowest: compound 2; then compound 1; then compound 3.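

Within the data shown here, compound 4 is reported as not active in this assay, without a number, so no step from compound 3 to compound 4 can be read. The compounds shown leave open which part of the 3-carboxy-4-chlorophenyl group this read-out depends on. No supporting evidence bears on this result.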